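The source may hold more compounds than are shown below. What is called first, only, known or untested is meant among the compounds shown, and "the series" means these compounds.

Measured so far in a functional assay on the whole organism (strain CF-1) with Mus musculus as the target, in the writhing test, with a stated time of 15 min; a lower number here means that less compound is needed, a higher number that more compound is needed for the effect:
compound 1 `O=C(/N=C1\NC2(CCCCO2)CCS1)c1ccccc1` gives 5 mg/kg;
compound 2 `O=C(/N=C1\NC2(CCCCO2)CCS1)c1cccc(F)c1` gives 9.2 mg/kg;
compound 3 `O=C(/N=C1\NC2(CCCCO2)CCS1)c1ccccc1Cl` reaches only a limit of the assay, > 200 mg/kg.

Among the two numbers, compound 1 stands lowest, with compound 2 nearest and within the scatter. Compound 4 `N#Cc1ccc(C(=O)/N=C2\NC3(CCCCO3)CCS2)cc1` differs from compound 1 by cyano in place of hydrogen on an aromatic carbon. Among the compounds with values here, two measured steps bear on this: a 1.8-fold higher number from compound 1 to compound 2 (0.26 log units; within the scatter), and an at least 40-fold higher number from compound 1 to compound 3 (1.60 log units; beyond the scatter), the latter resting on (the limit of > 200 mg/kg in this assay, at which 1 of the 3 values shown sits). A substituent on the aromatic ring thus ranged from no change to a large loss. For the cyano group a modest rise is expected, a 2.4-fold higher number from compound 1 to compound 4 (0.38 log units; beyond the scatter), with wide uncertainty. Compound 4 is therefore estimated at 12 mg/kg, between 3 mg/kg and 50 mg/kg.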

Compound 4, dose for half-maximal effect: 60 mg/kg
The estimate for compound 4 lay 5.0-fold (0.70 log units) below the measured number; the measured number lies above the stated range.
By their numbers in this assay, from the lowest: compounds 1 and 2 (each within the scatter of the next); then compound 4. At a limit, above all of these: compound 3.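

In this assay, cyano in place of hydrogen, para to a large group, gives a 12-fold higher number from compound 1 to compound 4 (1.08 log units; beyond the scatter), a large step, whereas the fluoro step gave a 1.8-fold higher number from compound 1 to compound 2 (0.26 log units; within the scatter). Unlike the step to compound 3, this large step rests on a measured number and not on a limit: the limit of > 200 mg/kg in this assay, at which 1 of the 4 values shown sits.

Compound 4 is the only one shown with a group at this position, which leaves open whether the step belongs to cyano itself or to any substituent there. As far as these compounds go, how a methoxy group or an amine would fare in this place also remains open.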